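Replacing a ring iodine with a cyclohexylmethyl amide

This account rests on a few compounds, and the source may have more. Where it says the series, first, only, none or still open, it means among the compounds named here.

Measured compounds:
Compound 1, `O=C1N/C(=C\c2ccc(O)cc2)C(=O)N1c1ccc(I)cc1`, 25500 nM
Compound 2, `O=C1N/C(=C\c2ccc(O)cc2)C(=O)N1c1cccc(I)c1`, > 200000 nM
Compound 3, `O=C1N/C(=C\c2ccc(O)cc2)C(=O)N1c1ccc(Br)cc1`, 69900 nM

All three share one core and differ only in the substituent on the aryl ring attached to the ring nitrogen. In a functional assay on NCI-H292 cells (Homo sapiens) for antiproliferative activity (a higher number here means a weaker inhibitor, a lower number a stronger inhibitor), compound 1 gives 25500 nM. Moving the iodine from the para to the meta position gives an at least 7.8-fold higher number from compound 1 to compound 2 (0.89 log units; beyond the scatter). For compound 2 the value > 200000 nM is only a limit of the assay, not a number, as shown by the limit of > 200000 nM in this assay, at which 1 of the 3 values shown sits, so compound 2 stands at the weak end of the three, with no exact figure. Swapping iodine for bromine gives a 2.7-fold higher number from compound 1 to compound 3 (0.44 log units; beyond the scatter), and from the limit compound to the bromo compound the step is an at least 2.8-fold lower number from compound 2 to compound 3 (0.45 log units; beyond the scatter).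

Compound 4, `O=C(NCC1CCCCC1)c1cccc(N2C(=O)N/C(=C\c3ccc(O)cc3)C2=O)c1`, arises from compound 2 by (cyclohexylmethyl)carbamoyl in place of iodo on an aromatic carbon. Within the data shown here, no measured step exchanges a halogen for an amide, so the two steps that bear on it, an at least 7.8-fold higher number from compound 1 to compound 2 (0.89 log units; beyond the scatter) and a 2.7-fold higher number from compound 1 to compound 3 (0.44 log units; beyond the scatter), only show that the aryl substituent can shift the result modestly or more. Since compound 2 already sits at the limit, the expected direction for compound 4 is toward a lower number, giving an estimated at least 2.2-fold lower number from compound 2 to compound 4 (0.34 log units; beyond the scatter). Compound 4 is therefore estimated at 90000 nM, within a range from 20000 nM to 300000 nM.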

Compound 4, half-maximal inhibitory concentration: 17900 nM
Estimate against measurement, compound 4: 5.0-fold (0.70 log units) above; measured number outside the range, below it.
By their numbers in this assay, from the lowest: compounds 4 and 1 (each within the scatter of the next); then compound 3. At a limit, above all of these: compound 2.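

In this assay, the place on the aromatic ring that holds the iodine in compound 2 proves open to change, as (cyclohexylmethyl)carbamoyl in place of iodo gives an at least 11-fold lower number from compound 2 to compound 4 (1.04 log units; beyond the scatter). Among these compounds, compound 2 has a limit and not a number, so this step has no exact size and its true extent remains unknown: the limit of > 200000 nM in this assay, at which 1 of the 4 values shown sits. The earlier compounds varied only a halogen or where it sat, whereas compound 4 shows that a far larger group, bringing a six-membered carbon ring and an amide, goes with a stronger result at this place, not a weaker one.

The compounds shown do not reveal which part of the new group matters, since the amide and the cyclohexylmethyl portion enter together, and a simple unsubstituted amide, a carboxylic acid or a plain cyclohexyl group at the same place would be needed to separate their contributions. On these data alone, it also remains open whether (cyclohexylmethyl)carbamoyl would give a similar result at the place held by the iodine in compound 1, or whether a longer chain between the amide and the cyclohexyl ring would change the number.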